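The source may report more compounds than this note shows. Statements on the series, on what has been measured and on what is new or still open speak of the compounds shown alone.

Measured so far:
Compound 1 `CC(C)(C)c1ccc(C(=O)N2CCC3(CC2)C(=O)N(CC(=O)N2CCCC(O)C2)CN3c2ccccc2)cc1`: 12200 nM
Compound 2 `O=C(CN1CN(c2ccccc2)C2(CCN(C(=O)c3ccc(C4CCCCC4)cc3)CC2)C1=O)NCCCCO`: 10300 nM

Both numbers come from an assay on HEK293 cells for displacement of a labelled ligand from NPC1-like intracellular cholesterol transporter 1 (Homo sapiens); a lower number here means a stronger inhibitor, a higher number a weaker inhibitor. In this assay compound 1 gives 12200 nM, and compound 2 gives 10300 nM. The two values lie within the scatter of each other, so neither compound can be called the stronger one; compound 2's nearest neighbour is compound 1, and the gap between them is of the size that repeat measurements alone would produce. Compound 3 `CC(C)(C)c1ccc(C(=O)N2CCC3(CC2)C(=O)N(CC(=O)NCCCCO)CN3c2ccccc2)cc1` has not yet been measured. It differs from compound 2 in a single place: tert-butyl in place of cyclohexyl on an aromatic carbon. Compound 1 already carries this same tert-butyl group, and its value and that of compound 2 are indistinguishable within the scatter. The step of a 1.2-fold higher number from compound 2 to compound 3 (0.07 log units; within the scatter) is therefore expected to be small and without a clear direction. Compound 3 is estimated at 12000 nM in this assay, with a range from 5000 nM to 30000 nM.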

Compound 3, half-maximal inhibitory concentration: 19200 nM
The estimate for compound 3 lay 1.6-fold (0.20 log units) below the measured number; measured number inside the range.
By their numbers in this assay, from the lowest: compounds 2, 1 and 3 (each within the scatter of the next).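

In this assay, tert-butyl in place of cyclohexyl on the aromatic carbon gives a 1.9-fold higher number from compound 2 to compound 3 (0.27 log units; within the scatter) and so, at this position para to a large group, a carbon-only ring and a carbon-only group with no ring cannot be told apart. A second single change, (4-hydroxybutyl)amino in place of 3-hydroxypiperidin-1-yl on the carbonyl carbon, gives a 1.6-fold higher number from compound 1 to compound 3 (0.20 log units; within the scatter) and so the open chain and the ring also cannot be told apart here, with both changes now read directly between matched compounds. No supporting measurement is available to account for these values. Going by these compounds, whether an amine or a carboxylic acid on this aromatic carbon would shift the number beyond the scatter remains open. So does the effect of a longer chain in place of the 4-hydroxybutyl group.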